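Aryl Sulfonate Changes and Antiproliferative Potency in M21 Cells

This account rests on a few compounds, and the source may have more. Where it says the series, first, only, none or still open, it means among the compounds named here.

Compound 1, `COc1ccccc1OS(=O)(=O)c1ccc(N2CCN(C)C2=O)cc1`: 21000 nM
Compound 2, `CN1CCN(c2ccc(S(=O)(=O)Oc3cccc(F)c3)cc2)C1=O`: 5800 nM
Compound 3, `Cc1ccc(OS(=O)(=O)c2ccc(N3CCN(C)C3=O)cc2)cc1`: a limit, > 100000 nM
Compound 4, `CN1CCN(c2ccc(S(=O)(=O)Oc3ccc(Cl)cc3)cc2)C1=O`: not yet measured

These compounds share one core and differ only in the aryl group on the sulfonate oxygen. In a functional assay on M21 cells (Homo sapiens) for antiproliferative activity, read by sulforhodamine B assay, with a stated time of 48 h (a higher number here means a weaker inhibitor, a lower number a stronger inhibitor), compound 1 gives 21000 nM, the higher of the two numbers recorded. Compound 2 gives 5800 nM, and the step is a 3.6-fold lower number from compound 1 to compound 2 (0.56 log units; beyond the scatter). For compound 3 the assay reports only a limit, > 100000 nM, namely (the limit of > 100000 nM in this assay, at which 1 of the 3 values shown sits). Against it, an at least 4.7-fold higher number from compound 1 to compound 3 (0.67 log units; beyond the scatter) and an at least 17-fold higher number from compound 2 to compound 3 (1.23 log units; beyond the scatter).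

Compound 4 carries 4-chlorophenyl in place of 2-methoxyphenyl on an oxygen. Within the data shown here, two measured steps bear on it and pull in opposite directions: moving from 2-methoxyphenyl to 3-fluorophenyl gave a modest gain, while moving to 4-methylphenyl gave an at least modest loss. Neither sets a clear direction for 4-chlorophenyl. Compound 4 is therefore expected to give roughly 25000 nM, within 6000 nM to 100000 nM. For compound 4 the expected step is a 1.2-fold higher number from compound 1 to compound 4 (0.08 log units; within the scatter), likely no larger than the scatter, with a real chance of only a limit.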

Compound 4, half-maximal inhibitory concentration: 43000 nM
Compound 4: middle estimate off by 1.7-fold (0.24 log units), on the low side, and the stated range covers the measured number.
By their numbers in this assay, from the lowest: compound 2; then compound 1; then compound 4. At a limit, above all of these: compound 3.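

Compound 4 shows that a halogen on the aryl group does not by itself bring the gain seen with 3-fluorophenyl: in this assay there is a 2.0-fold higher number from compound 1 to compound 4 (0.31 log units; beyond the scatter), and also a 7.4-fold higher number from compound 2 to compound 4 (0.87 log units; beyond the scatter). Chloro in place of methyl on an aromatic carbon gives an at least 2.3-fold lower number from compound 3 to compound 4 (0.36 log units; beyond the scatter), so 4-chlorophenyl yields a measured number where 4-methylphenyl does not. That step has only one measured end, as compound 3 is recorded as a limit and not as a number: the limit of > 100000 nM in this assay, at which 1 of the 4 values shown sits.

No pair shown separates the identity of the halogen from its place on the ring, as 3-fluorophenyl and 4-chlorophenyl differ in both. From the compounds shown here alone, it also remains open how 3-chlorophenyl, or an aryl group carrying an amine or a carboxylic acid, would read in this assay.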